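The source may report more compounds than this note shows. Statements on the series, on what has been measured and on what is new or still open speak of the compounds shown alone.

In a functional assay on the whole organism with Mus musculus as the target, in the formalin test (on this read-out higher numbers stand for an effect only at larger amounts of compound and lower numbers for an effect already at smaller amounts), compound 1 `O=C(Nc1ccc2[nH]c(O)nc2c1)C(=O)N1CCC(Cc2ccc(F)cc2)CC1` reads > 20 mg/kg, which is a limit of the assay and not a number. Compound 2 `O=C(Nc1ccc2[nH]c(O)nc2c1)C(=O)N1CCC(Cc2ccccc2)CC1` gives 14 mg/kg, and compound 3 `O=C(Nc1ccc2nc(O)oc2c1)C(=O)N1CCC(Cc2ccccc2)CC1` gives 0.9 mg/kg, the lower of the two numbers. Compound 4 `O=C(Nc1ccc2nc(O)oc2c1)C(=O)N1CCC(Oc2ccc(Cl)cc2)CC1` carries the change 4-chlorophenoxy in place of benzyl on a saturated ring carbon. For the measured compounds named here, the only measured step that bears on this is an at least 1.4-fold lower number from compound 1 to compound 2 (0.15 log units; that floor lies within the scatter), hydrogen in place of fluoro on an aromatic carbon, and its floor lies within the scatter. That step starts from the limit of > 20 mg/kg in this assay, at which 1 of the 3 values shown sits. Going by the values given here, no measured step covers the exchange of benzyl for 4-chlorophenoxy, so the guidance is thin. The expected change is a 1.7-fold higher number from compound 3 to compound 4 (0.22 log units; within the scatter), towards a higher number but not beyond the scatter. Compound 4 is estimated at 1.5 mg/kg, with an expected range from 0.4 mg/kg to 6 mg/kg.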

Compound 4, dose for half-maximal effect: 4.4 mg/kg
For compound 4 the middle estimate is 2.9-fold (0.47 log units) below the measured one, within the range that was stated.
By their numbers in this assay, from the lowest: compound 3; then compound 4; then compound 2. At a limit, above all of these: compound 1.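

In this assay, 4-chlorophenoxy in place of benzyl gives a 4.9-fold higher number from compound 3 to compound 4 (0.69 log units; beyond the scatter). This saturated ring carbon, three ring bonds from the ring nitrogen, therefore responds to an exchange of its group, which the earlier hydrogen-for-fluoro step on an aromatic carbon could not show. Nothing at hand accounts for the size of this step. Open, from the compounds shown here alone, is whether the oxygen or the chlorine carries the step, as 4-chlorophenoxy brings both at once; plain phenoxy would separate them. Also open, going by these compounds, is how an amine or a carboxylic acid would read on this ring carbon.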